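Lengthening the linker in a benzimidazole histamine antagonist series

The source may hold more compounds than are shown below. What is called first, only, known or untested is meant among the compounds shown, and "the series" means these compounds.

Three compounds have been measured in a functional assay on ileum for inhibition of histamine H1 receptor (Cavia porcellus); a higher number here means a weaker inhibitor, a lower number a stronger inhibitor:
compound 1, `C=CCOCCn1c(N2CCCN(C)CC2)nc2ccccc21`, 10 nM;
compound 2, `CCSCCn1c(N2CCN(C)CC2)nc2ccccc21`, 19 nM;
compound 3, `CN1CCCN(c2nc3ccccc3n2CCOc2ccccc2)CC1`, 9.1 nM.

Compound 2 gives the highest of these three numbers. Compound 1 is nearest to it, within the scatter, while compound 3 lies furthest away, beyond the scatter. Among the measured compounds shown here, the only step between measured compounds is a 1.1-fold lower number from compound 1 to compound 3 (0.04 log units; within the scatter), which exchanges the group on the oxygen and does not touch the chain length.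

Compound 4, `CCSCCCn1c(N2CCN(C)CC2)nc2ccccc21`, differs from compound 2 in one place: (ethylsulfanyl)methyl in place of ethylsulfanyl on a saturated chain carbon, two bonds along the chain from an aromatic nitrogen. For the measured compounds named here, no measured step in this assay changes the chain between the aromatic nitrogen and the sulfur, so the data give no direct guide. Compound 4 is therefore expected to give 25 nM, a range of 8 nM to 80 nM, meaning an estimated step of a 1.3-fold higher number from compound 2 to compound 4 (0.12 log units; within the scatter).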

Compound 4, half-maximal inhibitory concentration: 530 nM
The estimate for compound 4 lay 21-fold (1.33 log units) below the measured number; the measured number lies above the stated range.
By their numbers in this assay, from the lowest: compounds 3, 1 and 2 (each within the scatter of the next, the first and the last beyond it); then compound 4.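

Within this assay the change from ethylsulfanyl to (ethylsulfanyl)methyl on this saturated chain carbon gives a 28-fold higher number from compound 2 to compound 4 (1.45 log units; beyond the scatter) and so shows that the number responds strongly to chain length here. The earlier step, a 1.1-fold lower number from compound 1 to compound 3 (0.04 log units; within the scatter), changed only the group on the oxygen and stayed within the scatter. Nothing at hand explains the large rise. From the compounds shown here alone, whether the oxygen-linked chains of compound 1 and compound 3 respond in the same way to lengthening remains open. So does the effect of a shorter chain, or of an amine in place of the sulfur.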